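Working notes: ethoxycarbonyl on the ring of compound 1

A few compounds are considered here, and "the series" means these few. Any claim that something is new, unique, unknown or untested is made for them only; others in the source may bear on it.

- compound 1 `COc1ccc(Cn2c(C(=O)N3CCCCC3)cc3sccc32)cc1` gives > 100000 nM as a limit
- compound 2 `COc1ccc(Cn2c(C(=O)N3CCNCC3)cc3sccc32)cc1` gives > 100000 nM as a limit

In an ADME assay on HEK-293T cells (Homo sapiens) for cytotoxicity, read by luminescence, with a stated time of 24 h (on this read-out lower numbers stand for higher toxicity in this test and higher numbers for lower toxicity in this test), compound 1 stands at > 100000 nM which is a limit of the assay and not a number. Among the measured compounds shown here, compound 2 is likewise a limit at > 100000 nM in this assay so the series so far holds no measured number.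

For the measured compounds named here, the only measured change is a step that the two limits leave unreadable from compound 1 to compound 2 and it gives no size to carry forward. The picture on the numbers is therefore the limit of > 100000 nM in this assay, at which 2 of the 2 values shown sit, and nothing finer.

Compound 3 `CCOC(=O)C1CCN(C(=O)c2cc3sccc3n2Cc2ccc(OC)cc2)CC1` differs from compound 1 by ethoxycarbonyl in place of hydrogen on a saturated ring carbon with ethoxycarbonyl in place of hydrogen on a saturated ring carbon, three ring bonds from the ring nitrogen. Going by the values given here, no measured step speaks to this change, so no step beyond the scatter is expected and no direction is favoured.

The estimated change is a number no higher from compound 1 to compound 3 (the limit leaves the size open) and it should be read as an expectation only. For compound 3 the expected value is 100000 nM with an estimated range of 40000 nM to 200000 nM in this assay and a further limit is the likeliest report.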

Compound 3, half-maximal cytotoxic concentration: 39000 nM
For compound 3 the middle estimate is 2.6-fold (0.41 log units) above the measured one; measured number outside the range, below it.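

In this assay, among the compounds shown here, ethoxycarbonyl in place of hydrogen on a saturated ring carbon, three ring bonds from the ring nitrogen, gives the first readable step: an at least 2.5-fold lower number from compound 1 to compound 3 (0.40 log units; beyond the scatter), beyond the scatter. This shows that the amide ring of compound 1 is a place where a substituent can move the read-out towards higher toxicity in this test, which the earlier pair could not show: the step from compound 1 to compound 2 cannot be read, and the series otherwise rests on limits of the assay, not numbers: the limit of > 100000 nM in this assay, at which 2 of the 3 values shown sit. The size of the step from compound 1 to compound 3 is itself only a minimum, and the compounds shown give no cause for it.

Going by these compounds, whether the step belongs to the ester itself or to any substituent at this carbon stays open, and a carboxylic acid, a primary amide or a plain methyl group at the same place would separate these readings. On these data alone, it is also open whether ethoxycarbonyl would give a similar step on another carbon of the ring or on the ring of compound 2.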